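The source may hold more compounds than are shown below. What is called first, only, known or untested is meant among the compounds shown, and "the series" means these compounds.

In an ADME assay on a cell-free system (plasma, Homo sapiens) for protein binding, using equilibrium dialysis, with a stated time of 2 h (on this read-out higher numbers stand for a larger free fraction and lower numbers for a smaller free fraction), compound 1 `O/N=C(\Nc1ccc(F)c(Br)c1)c1nonc1NCc1ccccc1` gives < 0.005, which is a limit of the assay and not a number. Among the measured compounds shown here, compound 2 `CC(=O)NCCNc1nonc1/C(=N/O)Nc1ccc(F)c(Br)c1` gives 0.044, the only actual number so far in this assay. For the measured compounds named here, the single measured step is an at least 8.8-fold higher number from compound 1 to compound 2 (0.94 log units; beyond the scatter); it put acetamidomethyl in place of phenyl on a saturated chain carbon bound to a nitrogen on an aromatic ring. Compound 3 `CS(=O)(=O)NCCNc1nonc1/C(=N/O)Nc1ccc(F)c(Br)c1` has not yet been measured. It differs from compound 2 by methylsulfonyl in place of acetyl on an amine nitrogen, with methylsulfonyl in place of acetyl on an amine nitrogen, so that 2-acetamidoethyl becomes 2-(methanesulfonamido)ethyl. The step to compound 2 bears on this only loosely, since it exchanged a whole phenyl group, while the new change leaves the chain as it is and replaces only the acetyl. No shift beyond the scatter is therefore expected in this assay. The expected step is a 1.3-fold lower number from compound 2 to compound 3 (0.10 log units; within the scatter), an estimate rather than a result. Compound 3 is estimated at 0.035, with an expected range from 0.018 to 0.07.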

Compound 3, unbound fraction: 0.024
For compound 3 the middle estimate is 1.5-fold (0.16 log units) above the measured one; low and high end bracket the measured number.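

In this assay, methylsulfonyl in place of acetyl on an amine nitrogen gives a 1.8-fold lower number from compound 2 to compound 3 (0.26 log units; within the scatter), so at this position the two groups cannot be told apart on this read-out, even though methylsulfonyl brings one more heavy atom and one more hydrogen-bond acceptor. Compared with the phenyl-bearing compound, the sulfonyl-capped chain gives an at least 4.8-fold higher number from compound 1 to compound 3 (0.68 log units; beyond the scatter), which shows that the gain first seen with compound 2 is not tied to the acetyl and holds with methylsulfonyl as well. Compound 1 stands at a limit of the assay and not at a number, so this step gives only a minimum size: the limit of < 0.005 in this assay, at which 1 of the 3 values shown sits.

The compounds shown leave open whether a capped nitrogen is needed at all, since a free amine, a carboxylic acid or a longer chain in place of 2-acetamidoethyl could give a different reading. They also do not separate which part of the exchange away from phenyl carries the step, as compound 2 and compound 3 each differ from compound 1 by a whole group.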